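The compounds below may be only part of what the source reports. "The series", "measured", "known", "first", "only" and "open" are said of these compounds alone.

- Compound 1 `O=C(NCc1cc(Cl)ccc1-n1cnnn1)[C@@H]1C[C@@H]2C[C@@H]2N1C(=O)[C@H](O)c1cccc(Cl)c1`: > 500 mL.min-1.g-1 (a limit)
- Compound 2 `O=C(NCc1cc(Cl)ccc1-n1cnnn1)[C@@H]1C[C@@H]2C[C@@H]2N1C(=O)[C@H](O)C1CCCCC1`: 150 mL.min-1.g-1
- Compound 3 `O=C(NCc1cc(Cl)ccc1-n1cnnn1)[C@@H]1C[C@@H]2C[C@@H]2N1C(=O)[C@H](O)c1ccccc1F`: < 12 mL.min-1.g-1 (a limit)

All three compounds were tested in an ADME assay on liver for metabolic stability, with Liver microsome (Homo sapiens) as the target, read by LC-MS, using microsomes; on this read-out lower numbers stand for slow clearance and higher numbers for fast clearance. Compound 3 stands lowest of the three, and its < 12 mL.min-1.g-1 is a limit rather than a number. Compound 4 `O=C(NCc1cc(Cl)ccc1-n1cnnn1)[C@@H]1C[C@@H]2C[C@@H]2N1C(=O)[C@H](O)c1ccccc1` differs from it by hydrogen in place of fluoro on an aromatic carbon, with hydrogen in place of fluoro on an aromatic carbon, ortho to a large group. Two large steps bear on this change: an at least 41-fold lower number from compound 1 to compound 3 (1.61 log units; beyond the scatter) and an at least 12-fold lower number from compound 2 to compound 3 (1.09 log units; beyond the scatter). Both replace the whole group, and neither isolates the fluoro, so only a modest upward step is expected in this assay. The expected step is an at least 3.3-fold higher number from compound 3 to compound 4 (0.52 log units; beyond the scatter). For compound 4 the estimated value is 40 mL.min-1.g-1, within an expected range of 12 mL.min-1.g-1 to 150 mL.min-1.g-1.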

Compound 4, intrinsic clearance in microsomes: < 16 mL.min-1.g-1
Compound 4 ended at the assay's limit; the forecaster's own chance of this, stated with the estimate: 20%; middle value at least 2.5-fold (0.39 log units) from the limit.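

In this assay the value of compound 4 is a limit, as is that of compound 3, so the step between them, hydrogen in place of fluoro on an aromatic carbon, cannot be read: the limit of < 16 mL.min-1.g-1 in this assay, at which 1 of the 4 values shown sits. What compound 4 adds is that the low number does not depend on the fluoro: plain phenyl already stands far lower than the cyclohexyl (an at least 9.3-fold lower number from compound 2 to compound 4 (0.97 log units; beyond the scatter)) and the 3-chlorophenyl (an at least 31-fold lower number from compound 1 to compound 4 (1.49 log units; beyond the scatter)). From the compounds shown here alone, how far compound 3 and compound 4 lie apart stays open. So does whether a methoxy or an amine on this aromatic carbon would keep the number as low.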